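Chloro for Nitro: An Expected Flat Step

The source may hold more compounds than are shown below. What is called first, only, known or untested is meant among the compounds shown, and "the series" means these compounds.

In a functional assay on the whole organism (strain Albino) with Mus musculus as the target, with a stated time of 4 h (on this read-out lower numbers stand for an effect already at smaller amounts and higher numbers for an effect only at larger amounts of compound), compound 2 `C/C(=N/NC(=O)Nc1nc(-c2ccc(C)cc2)cc(-c2ccc(Cl)cc2)n1)c1ccc([N+](=O)[O-])cc1` gives 300 mg/kg. Compound 1 `C/C(=N/NC(=O)Nc1nc(-c2ccc(C)cc2)cc(-c2ccc(F)cc2)n1)c1ccc(Cl)cc1` gives 300 mg/kg in the same read-out, so the two stand level within the usual scatter. Compound 3 `C/C(=N/NC(=O)Nc1nc(-c2ccc(C)cc2)cc(-c2ccc(Cl)cc2)n1)c1ccc(Cl)cc1` has not yet been measured; it differs from compound 2 by chloro in place of nitro on an aromatic carbon. Among the compounds with values here, no measured pair shows this change, and the values of compound 1 and compound 2 give no sign of movement. The step is therefore expected to lie within the scatter: no change at the digits printed from compound 2 to compound 3 (within the scatter). For compound 3 the expected value is 300 mg/kg, with a range of 150 mg/kg to 600 mg/kg.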

Compound 3, dose for half-maximal effect: 300 mg/kg
The estimate for compound 3 equals the measured number at the digits printed; low and high end bracket the measured number.
By their numbers in this assay, from the lowest: compounds 1, 2 and 3 (each within the scatter of the next).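

In this assay, within the data shown here, the exchange of 4-nitrophenyl for 4-chlorophenyl, seen here in a measured pair for the first time, gives no change at the digits printed from compound 2 to compound 3 (within the scatter). Chloro in place of fluoro on an aromatic carbon, at the second place that varies, likewise gives no change at the digits printed from compound 1 to compound 3 (within the scatter), so neither exchange moves the read-out in these compounds. Nothing available here explains this flatness. On these data alone, whether an amine or a carboxylic acid at either place would move the value remains open. So does the effect of replacing the methyl group that all three compounds share.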